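This account rests on a few compounds, and the source may have more. Where it says the series, first, only, none or still open, it means among the compounds named here.

In an ADME assay on Vero cells (Chlorocebus sabaeus) for cytotoxicity, read by MTT assay, with a stated time of 48 h (a higher number here means that more compound is tolerated, a lower number that less compound is tolerated), compound 1 `C=C1CC[C@H]2[C@@](C)(CCC(=O)[C@@]2(C)COC(C)=O)[C@@H]1C/C=C1/C(=O)OC[C@H]1Oc1c(Cl)cc(Cl)c2cccnc12` gives 64700 nM and compound 2 `C=C1CC[C@@H]2[C@](C)(COC(C)=O)[C@H](O)CC[C@@]2(C)[C@@H]1C/C=C1/C(=O)OC[C@@H]1Oc1c(Cl)cc(Cl)c2cccnc12` gives 51900 nM, two values within the usual scatter of each other. Compound 3 `C=C1CC[C@H]2[C@@](C)(CCC(=O)[C@@]2(C)COC(C)=O)[C@@H]1C/C=C1/C(=O)OC[C@H]1Oc1cccc2ccc(C)nc12` keeps the core of compound 1 but carries 2-methylquinolin-8-yl in place of 5,7-dichloroquinolin-8-yl on an oxygen on a saturated carbon. For the measured compounds named here, no measured pair of compounds differing in one place shows how large such a change can be, so no step beyond the scatter is expected in this assay. The estimated step is a 1.2-fold higher number from compound 1 to compound 3 (0.06 log units; within the scatter). For compound 3 the expected value is 75000 nM, with an estimated range of 30000 nM to 180000 nM.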

Compound 3, half-maximal cytotoxic concentration: 72400 nM
Compound 3: middle estimate off by 1.0-fold (0.02 log units), on the high side; the measured number falls inside the stated range.
By their numbers in this assay, from the lowest: compounds 2, 1 and 3 (each within the scatter of the next).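

In this assay, for the compounds shown here, putting 2-methylquinolin-8-yl in place of 5,7-dichloroquinolin-8-yl on an oxygen on a saturated carbon gives a 1.1-fold higher number from compound 1 to compound 3 (0.05 log units; within the scatter) and this is the only step measured at this position. Within the usual scatter, this assay does not separate the two groups on the core of compound 1. Nothing available explains this result. The compounds shown leave open whether an amine or a carboxylic acid at this position would also stay within the scatter, and whether the same exchange would behave alike on the core of compound 2.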